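A few compounds are considered here, and "the series" means these few. Any claim that something is new, unique, unknown or untested is made for them only; others in the source may bear on it.

In a functional assay (aorta) with Rattus norvegicus as the target (a higher number here means that more compound is needed for the effect, a lower number that less compound is needed), three compounds with a shared core have been measured. Compound 1 (`COc1ccc(-c2nc(N=C(N)N)sc2-c2ccc(OC)cc2)cc1`) stands at 2 uM and compound 2 (`COc1ccc(-c2nc(/N=C(\N)N(C)C)sc2-c2ccc(OC)cc2)cc1`) at 4.8 uM while compound 3 (`COc1ccc(-c2nc(/N=C(\N)[N+]3(C)CCCCC3)sc2-c2ccc(OC)cc2)cc1`) stands at 21 uM as the highest number of the three. Compound 4 (`COc1ccc(-c2nc(CN)sc2-c2ccc(OC)cc2)cc1`) differs from compound 3 in one group (a group of 2 heavy atoms (1 carbon, 1 nitrogen; no ring) in place of a group of 10 heavy atoms (7 carbon, 3 nitrogen; one six-membered non-aromatic ring with 1 hetero atom), on an aromatic carbon). Aminomethyl, with no net charge, enters on an aromatic carbon of a five-membered aromatic ring with 1 nitrogen and 1 sulfur, and a group with net charge +1 leaves. For the measured compounds named here, three measured steps bear on this change: a larger group gave a 2.4-fold higher number from compound 1 to compound 2 (0.38 log units; beyond the scatter) and then a 4.4-fold higher number from compound 2 to compound 3 (0.64 log units; beyond the scatter) with an 11-fold higher number from compound 1 to compound 3 (1.02 log units; beyond the scatter) overall. The number therefore rose with group size in these three compounds. Aminomethyl is smaller than the group in compound 1 at 2 uM but no measured compound carries it, so this trend is only a loose guide. A modest drop is expected in this assay and the expected step is a 3.5-fold lower number from compound 3 to compound 4 (0.54 log units; beyond the scatter) with wide uncertainty. For compound 4 the estimated value is 6 uM with an expected range from 1.5 uM to 30 uM in this estimate.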

Compound 4, concentration for half-maximal effect: 7.7 uM
For compound 4 the middle estimate is 1.3-fold (0.11 log units) below the measured one; the measured number falls inside the stated range.
By their numbers in this assay, from the lowest: compound 1; then compounds 2 and 4 (each within the scatter of the next); then compound 3.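

In this assay the number rose with group size from compound 1 through compound 2 to compound 3, but compound 4 goes against that pattern: aminomethyl is the smallest of these groups, yet the change brings a 3.9-fold higher number from compound 1 to compound 4 (0.59 log units; beyond the scatter) rather than a lower number. Replacing the largest group, which carries a net charge, with aminomethyl gives a 2.7-fold lower number from compound 3 to compound 4 (0.44 log units; beyond the scatter) and so lowers the number, while a 1.6-fold higher number from compound 2 to compound 4 (0.21 log units; within the scatter) leaves those two compounds indistinguishable in this assay. Nothing available here explains this order.

On these data alone, it remains open whether a longer chain such as aminoethyl, or a carboxylic acid on the same aromatic carbon, would fall nearer compound 1 or compound 3. All four compounds keep both 4-methoxyphenyl groups, so it is also unknown whether this order would hold with other groups there.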